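The compounds below may be only part of what the source reports. "The series", "measured", "known", "first", "only" and "open" are said of these compounds alone.

In a functional assay on MCF7 cells (Homo sapiens) for cytotoxicity, read by sulforhodamine B assay (a lower number here means a stronger inhibitor of growth, a higher number a weaker inhibitor of growth), compound 3 `CC1=CC[C@@H]([C@@](C)(O)CCCC(C)(C)NC(=S)N/N=C\c2ccc([N+](=O)[O-])cc2)CC1` gives > 100000 nM, which is a limit of the assay and not a number. Compound 4 `CC1=CC[C@@H]([C@@](C)(O)CCCC(C)(C)NC(=S)N/N=C\c2ccc(Cl)cc2)CC1` keeps the shared core but has chloro in place of nitro on an aromatic carbon, para to a large group (chloro in place of nitro on an aromatic carbon).

Within the data shown here, no measured step makes this exact swap, so the evidence is indirect. Where compound 3 has nitro, compound 1 `COc1ccc(/C=N\NC(=S)NC(C)(C)CCC[C@](C)(O)[C@@H]2CC=C(C)CC2)cc1` has methoxy, and compound 1 gives 94900 nM. That exchange amounts to an at least 1.0-fold higher number from compound 1 to compound 3 (0.02 log units; that floor lies within the scatter), so it shows no clear effect from replacing one group with another at this place. Compound 2 `CC1=CC[C@@H]([C@@](C)(O)CCCC(C)(C)NC(=S)N/N=C\c2cccc([N+](=O)[O-])c2)CC1` carries the nitro group at another place on the ring and gives 18300 nM. The step of an at least 5.4-fold higher number from compound 2 to compound 3 (0.73 log units; beyond the scatter) shows that moving a group can matter, but compound 4 involves no such move.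

A small or modest shift toward a lower number therefore seems most likely, and the expected step is an at least 1.6-fold lower number from compound 3 to compound 4 (0.22 log units; that floor lies within the scatter). For compound 4, the estimated value is 60000 nM, with an expected range of 20000 nM to 120000 nM.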

Compound 4, concentration for total growth inhibition: 15800 nM
Compound 4: middle estimate off by 3.8-fold (0.58 log units), on the high side; measured number below the stated range.
By their numbers in this assay, from the lowest: compounds 4 and 2 (each within the scatter of the next); then compound 1. At a limit, above all of these: compound 3.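

In this assay, the group at this place on the ring clearly matters: chloro gives an at least 6.3-fold lower number from compound 3 to compound 4 (0.80 log units; beyond the scatter) and a 6.0-fold lower number from compound 1 to compound 4 (0.78 log units; beyond the scatter), whereas nitro and methoxy at this place had shown no clear difference. The comparison with the other nitro compound gives a 1.2-fold lower number from compound 2 to compound 4 (0.06 log units; within the scatter), so compound 4 and compound 2 cannot be told apart, although both the group and its place on the ring differ. The value of compound 3 is a limit of the assay and not a number, so its step to compound 4 gives only a floor: the limit of > 100000 nM in this assay, at which 1 of the 4 values shown sits.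

The compounds shown leave open how a fluoro group, a methyl group or an amine at this place would compare with chloro. They also leave open whether chloro would give a similar result in the ring place held by the nitro group of compound 2.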